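Swapping the benzyl arm for a hydroxy-phenylethyl arm

A few compounds are considered here, and "the series" means these few. Any claim that something is new, unique, unknown or untested is made for them only; others in the source may bear on it.

Compound 3 `Cc1ccc2[nH]c(=O)c(CN(Cc3ccc(OCCO)cc3)Cc3ccc(C(C)(C)C)cc3)cc2c1` is one of three close relatives tested in a toxicity assay on MDCK cells (Canis lupus familiaris) for cytotoxicity, read by crystal violet staining, with a stated time of 48 h; a lower number here means that less compound is tolerated, a higher number that more compound is tolerated. In this assay compound 3 gives > 5000 nM, a limit of the assay rather than a measured number. Compound 1 `Cc1ccc2[nH]c(=O)c(CN(Cc3ccccc3)Cc3ccc(C(C)(C)C)cc3)cc2c1` differs from it only in lacking the 2-hydroxyethoxy group; in this assay compound 1 gives > 5000 nM, which is likewise a limit. Compound 2 `COc1ccc(CN(Cc2ccc(C(C)(C)C)cc2)Cc2cc3cc(C)ccc3[nH]c2=O)cc1` carries a methoxy in that place instead; in this assay compound 2 gives > 10000 nM, again a limit. Compound 3 therefore stands at the limit of > 5000 nM in this assay, at which 2 of the 3 values shown sit, and the remaining value stands at the limit of > 10000 nM in this assay, at which 1 of the 3 values shown sits.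

The measured steps that bear on this series are a step that the two limits leave unreadable from compound 1 to compound 3, a step that the two limits leave unreadable from compound 2 to compound 3 and a step that the two limits leave unreadable from compound 1 to compound 2; none of them can be read as a size, so they set no direction.

Compound 4 `Cc1ccc2[nH]c(=O)c(CN(Cc3ccc(C(C)(C)C)cc3)[C@H](CO)c3ccccc3)cc2c1` is made from compound 3 by 2-hydroxy-1-phenylethyl in place of 4-(2-hydroxyethoxy)benzyl on an amine nitrogen. With no readable step to build on, and all three relatives tolerated up to their limits, the expectation for compound 4 in this assay is a step that the limit leaves unreadable from compound 3 to compound 4, which is none beyond the scatter. Compound 4 is thus estimated at 8000 nM, with a likely range from 3000 nM to 25000 nM, and most probably reported as a limit again.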

Compound 4, half-maximal cytotoxic concentration: > 10000 nM
Compound 4 was reported as a limit (the forecaster's own chance of this, stated with the estimate: 70%); at least 1.2-fold (0.09 log units) between middle value and limit.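

All four values in this assay are limits of the assay, so the steps from compound 1, compound 2 and compound 3 to compound 4 cannot be read as sizes. The compounds shown leave open how much of each compound the cells tolerate, and so whether the 2-hydroxy-1-phenylethyl arm differs at all from the 4-(2-hydroxyethoxy)benzyl arm.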